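Trifluoromethyl for Methyl on a Second Core

The source may report more compounds than this note shows. Statements on the series, on what has been measured and on what is new or still open speak of the compounds shown alone.

Three compounds have been measured in a functional assay on U-251 cells (Homo sapiens) for cytotoxicity, read by sulforhodamine B assay, with a stated time of 48 h, tested at 50 uM; on this read-out higher numbers stand for more inhibition at the one concentration tested (going by the name of the read-out) and lower numbers for less inhibition:

Compound 1 `FC(F)(F)c1ccc(Nc2nccc(-c3cnc4ccccc4c3)n2)cc1` gives 49.8%.
Compound 2 `Cc1ccc(Nc2nccc(-c3c(C)nc4ccccn34)n2)cc1` gives 100%.
Compound 3 `Cc1ccc(Nc2nccc(-c3cnc4ccccc4c3)n2)cc1` gives 87.7%.

Compound 2 stands highest of the three, with compound 3 nearer to it and compound 1 furthest away. The difference between the core of compound 2 and the core of compound 3 is not broken down here. Within the core of compound 3, the change trifluoromethyl in place of methyl on an aromatic carbon produced a number 37.9 percentage points lower from compound 3 to compound 1 (beyond the scatter).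

Compound 4 `Cc1nc2ccccn2c1-c1ccnc(Nc2ccc(C(F)(F)F)cc2)n1` is not yet measured. It differs from compound 2 by trifluoromethyl in place of methyl on an aromatic carbon, the same change in the same place as that from compound 3 to compound 1. Because compound 2 starts at 100%, a drop of comparable size is expected, giving an estimated a number 35 percentage points lower from compound 2 to compound 4 (beyond the scatter). Compound 4 is therefore expected to give about 65%, likely between 35% and 95%.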

Compound 4, a percentage reported as inhibition, at one concentration (the size of the read-out at that concentration, not a potency): 85.6%
The estimate for compound 4 lay 20.6 percentage points below the measured number; the measured number falls inside the stated range.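

In this assay, trifluoromethyl in place of methyl on an aromatic carbon went the same way on the core of compound 2, with a number 14.4 percentage points lower from compound 2 to compound 4 (beyond the scatter). The direction of the change thus carried over from one core to the other, but its size did not: the same change on two cores in this assay, a number 37.9 percentage points lower (beyond the scatter) from compound 3 to compound 1 and a number 14.4 percentage points lower (beyond the scatter) from compound 2 to compound 4, 23.5 percentage points apart, beyond the scatter of two such steps. For the compounds shown here, with only one pair on each core, this does not show why the two steps differ, or what the change would do on any further core.

The compounds shown leave open whether another group in the same place, such as a chlorine atom, a methoxy group or an amine, would give a step like either of these. From the compounds shown here alone, each number is also a reading at one concentration, so how potency moves with the change remains open.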